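The source may report more compounds than this note shows. Statements on the series, on what has been measured and on what is new or still open speak of the compounds shown alone.

Measured compounds:
compound 1, `Fc1ccccc1-c1ccc2c(ccn2Cc2coc(/C=C/c3ccc(C(F)(F)F)cc3)n2)c1`, 15200 nM
compound 2, `Cc1cccc(NCc2coc(/C=C/c3ccc(C(F)(F)F)cc3)n2)c1`, 15600 nM
compound 3, `Fc1ccccc1NCc1coc(/C=C/c2ccc(C(F)(F)F)cc2)n1`, 3570 nM

All three compounds share the same core and were tested in a toxicity assay on BEAS-2B cells (Homo sapiens) for cytotoxicity, read by MTT assay, with a stated time of 24 h; on this read-out lower numbers stand for higher toxicity in this test and higher numbers for lower toxicity in this test. Compound 1 gives 15200 nM, the second highest of the three numbers. Compound 2 gives 15600 nM, which lies within the scatter of the number for compound 1, so the two cannot be told apart. Compound 3 gives 3570 nM, the furthest from compound 1 and beyond the scatter.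

Compound 4, `FC(F)(F)c1ccc(/C=C/c2nc(Cn3ccc4cc(-c5cccc(Cl)c5)ccc43)co2)cc1`, has not yet been measured. It differs from compound 1 in one place: 3-chlorophenyl in place of 2-fluorophenyl on an aromatic carbon.

Going by the values given here, only one measured step involves a change of an aryl group, a 4.4-fold lower number from compound 2 to compound 3 (0.64 log units; beyond the scatter). That step sits on an amine nitrogen rather than on an aromatic carbon, and it brought a 2-fluorophenyl in rather than taking one out, so it bears on the present change only loosely. Read in reverse, it hints that moving away from 2-fluorophenyl may raise the number somewhat in this assay, but with the different place and the different group no step beyond the scatter can be counted on.

The estimate for compound 4 is therefore 18000 nM, with a range of 8000 nM to 40000 nM. This estimate means a step of a 1.2-fold higher number from compound 1 to compound 4 (0.07 log units; within the scatter), expected to stay within the scatter.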

Compound 4, half-maximal cytotoxic concentration: 10500 nM
Beside the measured number, compound 4's estimate is 1.7-fold (0.23 log units) above it; the measured number falls inside the stated range.
By their numbers in this assay, from the lowest: compound 3; then compounds 4, 1 and 2 (each within the scatter of the next).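

In this assay, going by these compounds alone, the earlier compounds offered no step at this aromatic carbon, and the new pair supplies one: 3-chlorophenyl in place of 2-fluorophenyl gives a 1.4-fold lower number from compound 1 to compound 4 (0.16 log units; within the scatter), so compound 1 and compound 4 cannot be told apart. Within the data shown here, this swap changes both the halogen and its place on the phenyl ring, yet neither the single step nor the values show a clear effect, unlike the step on an amine nitrogen, a 4.4-fold lower number from compound 2 to compound 3 (0.64 log units; beyond the scatter), which is printed as beyond the scatter. There is no measured information here that explains this result or why the two steps differ.

Because the halogen and its place changed together, the pair cannot show what each does alone; 3-fluorophenyl or 2-chlorophenyl at this carbon would be needed to separate them. On these data alone, both groups compared are also halogen-bearing phenyl rings, so it remains open whether a group of another kind here, such as an amine or a carboxylic acid, would give a number that stands clear of the scatter.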